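Hydroxyphenyl Replaces Benzodioxinyl on the Benzamide Aryl

The source may hold more compounds than are shown below. What is called first, only, known or untested is meant among the compounds shown, and "the series" means these compounds.

Compound 2 `CCOC(=O)CCCCCOc1cccc(CN(C(=O)c2ccc(-c3ccc4c(c3)OCCO4)cc2)C(C)C)c1` was tested in an ADME assay on BJ cells (Homo sapiens) for cytotoxicity, read by CellTiter-Glo and resazurin assay, with a stated time of 72 h (a higher number here means that more compound is needed for the effect, a lower number that less compound is needed), and gives only a limit, > 24400 nM. Its neighbour compound 1 `CCOC(=O)CCCCCOc1cccc(CN(C(=O)c2ccc(-c3cccc(-c4ccccc4)c3)cc2)C(C)C)c1` likewise reaches only a limit in this assay, > 26000 nM. The step that the two limits leave unreadable from compound 1 to compound 2 is therefore not readable, since both values sit at the edges of the assay the limit of > 24400 nM in this assay, at which 1 of the 2 values shown sits (the limit of > 26000 nM in this assay, at which 1 of the 2 values shown sits). Compound 3 `CCOC(=O)CCCCCOc1cccc(CN(C(=O)c2ccc(-c3cccc(O)c3)cc2)C(C)C)c1` differs from compound 2 in one place: 3-hydroxyphenyl in place of 2,3-dihydro-1,4-benzodioxin-6-yl on an aromatic carbon. For the measured compounds named here, no measured step speaks directly to this change, and the only step available is itself unreadable. The expectation for compound 3 is a third limit rather than a number, so that the step that the limit leaves unreadable from compound 2 to compound 3 is expected to be none beyond the scatter. Compound 3 is estimated at 30000 nM, with a range from 10000 nM to 100000 nM, and will most likely be reported only as a limit.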

Compound 3, half-maximal effective concentration: > 26000 nM
Compound 3: only a limit was reported; the forecaster's own chance of this, stated with the estimate: 85%; the middle value does not contradict the limit.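

Compound 3, like compound 1 and compound 2, gives only a limit in this assay, so the steps among these three compounds cannot be read. The compounds shown leave open whether exchanging these groups changes the concentration needed for cytotoxicity at all, and by how much.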